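Chloro in place of pyrrolidin-1-yl on the shared core

The source may hold more compounds than are shown below. What is called first, only, known or untested is meant among the compounds shown, and "the series" means these compounds.

Compound 1 `CNc1nc(NC)nc(NC2(C#N)CCCCC2)n1` is measured in an in vitro assay on Sf21 cells for inhibition of high affinity 3',5'-cyclic-AMP phosphodiesterase 7A (Homo sapiens) (a lower number here means a stronger inhibitor, a higher number a weaker inhibitor), and gives only a limit, > 1000 nM. Compound 2 `CNc1nc(NC2(C#N)CCCCC2)nc(N2CCCC2)n1` likewise gives only a limit in this assay, > 5000 nM. Compound 3 `CNc1nc(NC2(C#N)CCCCC2)nc(-n2cnc3ccccc32)n1` also sits at a limit in this assay, > 1000 nM. Compound 2 thus stands with a limit only, as do the other two values shown. The step that the two limits leave unreadable from compound 1 to compound 2 is not readable from two limits. Compound 4 `CNc1nc(Cl)nc(NC2(C#N)CCCCC2)n1` carries the change (chloro in place of pyrrolidin-1-yl on an aromatic carbon). For the measured compounds named here, no measured step bears on this change except a step that the two limits leave unreadable from compound 1 to compound 2, which the limits leave unreadable; all values sit at the limit of > 1000 nM in this assay, at which 2 of the 3 values shown sit, or (the limit of > 5000 nM in this assay, at which 1 of the 3 values shown sits), so no direction can be read. Compound 4 is expected to stay near the limit, at 3000 nM with a range from 800 nM to 15000 nM. The expected step of an at least 1.6-fold lower number from compound 2 to compound 4 (0.22 log units; that floor lies within the scatter) therefore cannot be set against any readable measured step.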

Compound 4, half-maximal inhibitory concentration: 1070 nM
Beside the measured number, compound 4's estimate is 2.8-fold (0.45 log units) above it; the measured number falls inside the stated range.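

In this assay, for the compounds shown here, chloro in place of pyrrolidin-1-yl on this aromatic carbon gives an at least 4.6-fold lower number from compound 2 to compound 4 (0.66 log units; beyond the scatter) as the only readable step. Going by these compounds alone, the group at this position therefore does move the read-out, which the limits of the earlier compounds could not show. The step from compound 1 to compound 4 cannot be read.

Open, on these data alone, is whether methoxy, bromo or a primary amine at this position would lie on either side of chloro. Also open, as far as these compounds go, is whether the step holds with a group other than methylamino elsewhere on the shared core.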